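This account rests on a few compounds, and the source may have more. Where it says the series, first, only, none or still open, it means among the compounds named here.

Working notes on the series. Compound 1 `O=C1O[C@@H](CO)CN1c1ccc(-n2cc(-c3ccccn3)cn2)c(F)c1` gives 1.67 in a physicochemical assay for lipophilicity, read by HPLC, measured as octanol-water partition; on this read-out higher numbers stand for higher lipophilicity and lower numbers for lower lipophilicity. Compound 2 `COC(=O)CC1CCN(C[C@H]2CN(c3ccc(-n4cc(-c5ccccn5)cn4)c(F)c3)C(=O)O2)CC1` gives 1.78 in this assay, and compound 3 `O=C1O[C@@H](Cn2ccnc2)CN1c1ccc(-n2cc(-c3ccccn3)cn2)c(F)c1` gives 1.73, so compound 3 stands second highest of the three, within the scatter of both neighbours. The exchanges at the same place, a number 0.06 log units higher from compound 1 to compound 3 (within the scatter) and a number 0.05 log units lower from compound 2 to compound 3 (within the scatter), both stayed within the scatter, as did a number 0.11 log units higher from compound 1 to compound 2 (within the scatter). Compound 4 `CCC(=O)NC[C@H]1CN(c2ccc(-n3cc(-c4ccccn4)cn3)c(F)c2)C(=O)O1` carries the change (propanoylamino in place of 1H-imidazol-1-yl on a saturated chain carbon bound to a saturated ring carbon). Every exchange at this carbon so far has left the partition coefficient unmoved beyond the scatter; on that basis the expected step is a number 0.03 log units lower from compound 3 to compound 4 (within the scatter), none beyond the scatter. Compound 4 is therefore estimated at 1.7, with a range from 1.3 to 2.1.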

Compound 4, partition coefficient: 2.2
The estimate for compound 4 lay 0.50 log units below the measured number; the whole stated range lies below it.
By their numbers in this assay, from the lowest: compounds 1, 3 and 2 (each within the scatter of the next); then compound 4.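

For the compounds shown here, this carbon is not indifferent in this assay: propanoylamino is the first group here to stand apart beyond the scatter, with a number 0.47 log units higher from compound 3 to compound 4 (beyond the scatter) and a number 0.42 log units higher from compound 2 to compound 4 (beyond the scatter) and a number 0.53 log units higher from compound 1 to compound 4 (beyond the scatter). Hydroxy, 1H-imidazol-1-yl and 4-((methoxycarbonyl)methyl)piperidin-1-yl remain within the scatter of one another, so the change separates compound 4 from all three without ordering them. Nothing available bears on the origin of this step.

As far as these compounds go, whether an acetylamino group, a longer acyl chain or a plain amine at this carbon would go with compound 4 or with compounds 1, 2 and 3 remains open.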